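Piperazin-1-yl in place of pentylamino: the next step

The compounds below may be only part of what the source reports. "The series", "measured", "known", "first", "only" and "open" are said of these compounds alone.

Of the compounds shown here, three of one shared core have been measured in a functional assay on the whole organism (strain Wistar) for inhibition, with Rattus norvegicus as the target, read by paw edema, with stated times of 60 min and 6 h, at a dose of 100 mg/kg by the oral route; on this read-out higher numbers stand for more inhibition at the one dose given (going by the name of the read-out) and lower numbers for less inhibition. Compound 1 `COc1cc2c(cc1OC)C(CC(N)=O)CC2` gives 27.8%, compound 2 `CCCCCNC(=O)CC1CCc2cc(OC)c(OC)cc21` gives 35.2%, and compound 3 `COc1cc2c(cc1OC)C(CC(=O)N1CCCC1)CC2` gives 22.2%. Compound 2 holds the highest of the three numbers, although compound 1 lies within the scatter of it, a number 7.4 percentage points higher from compound 1 to compound 2 (within the scatter); only compound 3 sits clearly apart, a number 13 percentage points lower from compound 2 to compound 3 (beyond the scatter). The remaining pair is also close, a number 5.6 percentage points lower from compound 1 to compound 3 (within the scatter).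

The step to compound 4 `COc1cc2c(cc1OC)C(CC(=O)N1CCNCC1)CC2` is piperazin-1-yl in place of pentylamino on a carbonyl carbon.

For the measured compounds named here, of the measured steps, the one from compound 2 to compound 3 bears most directly on this, since it likewise replaced pentylamino on the carbonyl carbon with a ring-bearing amine and produced a modest fall beyond the scatter, a number 13 percentage points lower from compound 2 to compound 3 (beyond the scatter). The step from compound 1 to compound 3 was small, a number 5.6 percentage points lower from compound 1 to compound 3 (within the scatter), so the ring-bearing amides so far land near or below compound 1. A downward step of roughly that size is therefore expected in this assay, a number 13.2 percentage points lower from compound 2 to compound 4 (beyond the scatter). Compound 4 is estimated at 22%, with a range from 10% to 34% expected to hold most repeats.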

Compound 4, a percentage reported as inhibition, in the whole organism at one dose (the size of the read-out at that dose, not a potency): 33.3%
Compound 4: the middle estimate sits 11.3 percentage points below what was measured; low and high end bracket the measured number.
By their numbers in this assay, from the lowest: compounds 3, 1, 4 and 2 (each within the scatter of the next, the first and the last beyond it).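

In this assay, a ring on the carbonyl carbon does not by itself bring the loss that pyrrolidin-1-yl showed, for piperazin-1-yl in place of pentylamino gives a number 1.9 percentage points lower from compound 2 to compound 4 (within the scatter) and leaves the two compounds indistinguishable. The identity of the ring does register at this position: the exchange of one ring for the other gives a number 11.1 percentage points higher from compound 3 to compound 4 (beyond the scatter), the first modest rise among the steps at this carbonyl carbon, while the step from the plain amide gives a number 5.5 percentage points higher from compound 1 to compound 4 (within the scatter) and so separates nothing. Across these four compounds, then, only pyrrolidin-1-yl stands apart from pentylamino and piperazin-1-yl, and nothing at hand accounts for the gap between the two rings.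

The compounds shown leave open whether morpholin-4-yl, with an oxygen in place of the second ring nitrogen, or 4-methylpiperazin-1-yl would follow piperazin-1-yl or pyrrolidin-1-yl. They also leave open whether a butylamino or hexylamino chain would stay level with pentylamino, and how any of these amides would behave at other oral doses.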